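A few compounds are considered here, and "the series" means these few. Any claim that something is new, unique, unknown or untested is made for them only; others in the source may bear on it.

Measured so far:
compound 1, `Cc1ccccc1-n1cc(-c2ccccc2NS(=O)(=O)c2c[nH]c(=O)[nH]c2=O)nn1`: 56600 nM
compound 2, `O=c1[nH]cc(S(=O)(=O)Nc2cccc(-c3cn(-c4ccccc4)nn3)c2)c(=O)[nH]1`: a limit of the assay, > 100000 nM
compound 3, `Cc1ccc(-n2cc(-c3cccc(NS(=O)(=O)c4c[nH]c(=O)[nH]c4=O)c3)nn2)cc1`: 23100 nM

In an ADME assay on L02 cells (Homo sapiens) for cytotoxicity, read by MTT assay, with a stated time of 24 h (on this read-out higher numbers stand for lower toxicity in this test and lower numbers for higher toxicity in this test), compound 3 gives 23100 nM, the lowest of the two numbers shown; the nearest is compound 1, which gives 56600 nM. For compound 2 the assay reports only a limit, > 100000 nM. Compound 4, `O=c1[nH]cc(S(=O)(=O)Nc2cccc(-c3cn(-c4ccc(F)cc4)nn3)c2)c(=O)[nH]1`, which has not been measured, differs from compound 3 by fluoro in place of methyl on an aromatic carbon.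

Going by the values given here, one measured step touches the same position: an at least 4.3-fold lower number from compound 2 to compound 3 (0.63 log units; beyond the scatter), from a plain phenyl to the methyl-bearing one, and the starting value of that step sits at the limit of > 100000 nM in this assay, at which 1 of the 3 values shown sits. Taking the methyl away thus coincided with a clearly higher number, and compound 4 also lacks that methyl, while carrying a fluoro instead. Among the compounds with values here, no measured pair shows what fluoro does here, so the direction is taken from the methyl step, but with a wide margin. Compound 4 is therefore expected to show a modest rise, a 1.9-fold higher number from compound 3 to compound 4 (0.29 log units; within the scatter). Compound 4 is estimated at 45000 nM, within 15000 nM to 150000 nM.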

Compound 4, half-maximal cytotoxic concentration: "not toxic" (no number reported)
Compound 4 has no reported number here; no gap can be computed for the estimate.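

In this assay compound 4 is reported only as "not toxic", with no number, so no new step can be read between it and compound 3 or compound 2. The compounds shown leave open how 4-fluorophenyl compares numerically with 4-methylphenyl or plain phenyl.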